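Swapping the Pyrazole for an Isoxazole on a Biaryl

The compounds below may be only part of what the source reports. "The series", "measured", "known", "first", "only" and "open" are said of these compounds alone.

Within the data shown here, in an assay on isolated protein for inhibition of tyrosine-protein kinase receptor UFO (Homo sapiens), read by LC-MS (a lower number here means a stronger inhibitor, a higher number a weaker inhibitor), compound 2 `Cc1nn(C)c(C)c1-c1ccc(-c2nnc(N(C)Cc3ccc4nccn4c3)o2)cc1` gives 1260 nM, the upper of the two numbers measured so far, although a 2.0-fold higher number from compound 1 to compound 2 (0.30 log units; within the scatter) keeps it and compound 1 `Cc1ccccc1-c1ccc(-c2nnc(N(C)Cc3ccc4nccn4c3)o2)cc1`, which gives 631 nM, within the scatter. Compound 3 `Cc1noc(C)c1-c1ccc(-c2nnc(N(C)Cc3ccc4nccn4c3)o2)cc1` has not been measured; it differs from compound 2 in that (3,5-dimethyl-1,2-oxazol-4-yl in place of 1,3,5-trimethyl-1H-pyrazol-4-yl on an aromatic carbon). Among the measured compounds shown here, no measured step exchanges one five-membered ring for another, and the only step available, a 2.0-fold higher number from compound 1 to compound 2 (0.30 log units; within the scatter), was small. The expected step is therefore a 1.1-fold lower number from compound 2 to compound 3 (0.06 log units; within the scatter), nothing beyond the scatter. Compound 3 is estimated at 1100 nM, with a range from 450 nM to 2800 nM.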

Compound 3, half-maximal inhibitory concentration: 31600 nM
Beside the measured number, compound 3's estimate is 29-fold (1.46 log units) below it; the whole stated range lies below it.
By their numbers in this assay, from the lowest: compounds 1 and 2 (each within the scatter of the next); then compound 3.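

Measured by this assay, this position proves sensitive to the choice of five-membered ring, which the earlier pair, within the scatter of each other, did not reveal. 3,5-Dimethyl-1,2-oxazol-4-yl in place of 1,3,5-trimethyl-1H-pyrazol-4-yl gives a 25-fold higher number from compound 2 to compound 3 (1.40 log units; beyond the scatter) even though both rings hold two hetero atoms, and in place of 2-methylphenyl it gives a 50-fold higher number from compound 1 to compound 3 (1.70 log units; beyond the scatter) as well. No measurement here explains this loss. From the compounds shown here alone, whether the ring oxygen or the lost methyl group matters stays open. So does how a pyridine ring or an amine would behave at this position.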